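A few compounds are considered here, and "the series" means these few. Any claim that something is new, unique, unknown or untested is made for them only; others in the source may bear on it.

Compound 3 `CCc1nc2c(C)cc(C)nc2n1Cc1ccc(OC(C(=O)O)c2ccccc2)c(Cl)c1` gives the lowest number of the three measured compounds in an assay on Midbrain with Type-2 angiotensin II receptor (Rattus norvegicus) as the target (a lower number here means a stronger inhibitor, a higher number a weaker inhibitor), at 720 nM. Compound 1 `CCc1nc2c(C)cc(C)nc2n1Cc1ccc(OC(C(=O)O)c2ccccc2C)cc1` gives 5200 nM in this assay, and compound 2 `CCc1nc2c(C)cc(C)nc2n1Cc1ccc(OC(C(=O)O)c2ccccc2Cl)cc1` gives 15000 nM. Among the measured compounds shown here, the one measured step that changes a single place, the exchange of a methyl for a chloro on an aromatic carbon, runs a 2.9-fold higher number from compound 1 to compound 2 (0.46 log units; beyond the scatter).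

Compound 4 `CCCCc1cc(Cn2c(CC)nc3c(C)cc(C)nc32)ccc1OC(C(=O)O)c1ccccc1` differs from compound 3 in one place: butyl in place of chloro on an aromatic carbon. This change sits on a different ring from the methyl-to-chloro exchange between compound 1 and compound 2, so that step bears on it only loosely; it shows that swapping a chloro for a carbon group at an aromatic carbon can move the number by a modest amount, here in the direction of a higher number when chloro entered. For the measured compounds named here, no measured step replaces a chloro with a four-carbon chain at the position concerned.

The expectation for compound 4 in this assay is therefore a step of a 2.1-fold higher number from compound 3 to compound 4 (0.32 log units; beyond the scatter), most likely within or just beyond the scatter. Compound 4 is estimated at 1500 nM, with a range from 300 nM to 8000 nM.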

Compound 4, half-maximal inhibitory concentration: 140 nM
Compound 4: middle estimate off by 11-fold (1.03 log units), on the high side, outside the stated range (below it).
By their numbers in this assay, from the lowest: compound 4; then compound 3; then compound 1; then compound 2.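

Exchanging chloro for butyl gives a 5.1-fold lower number from compound 3 to compound 4 (0.71 log units; beyond the scatter) in this assay, so this position, ortho to a large group and meta to a large group, can carry a butyl chain of 4 carbon atoms and still give a lower number than with a single chlorine atom. The earlier methyl-to-chloro step lay on a different ring and could not show this, since it said nothing about a chain at this position. No measurement shown here accounts for the drop in the number.

On these data alone, whether a shorter ethyl, a longer hexyl or an amine at this position would lower the number further remains open. Also open, as far as these compounds go, is whether butyl would give a similar step in compounds with a methyl or chloro on the other ring, like compound 1 and compound 2.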